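The source may report more compounds than this note shows. Statements on the series, on what has been measured and on what is new or still open speak of the compounds shown alone.

Measured compounds:
compound 1 `CCOC(=O)Nc1sc(-c2ccc(Cl)cc2)c(-c2ccc(Cl)cc2)c1C(=O)NC1CC1` — 39800 nM
compound 2 `COc1ccc(CNC(=O)c2c(N)sc(-c3ccc(Cl)cc3)c2-c2ccc(Cl)cc2)cc1` — 18200 nM

In a functional assay on A549 cells (Homo sapiens) for inhibition, read by sulforhodamine B assay, with a stated time of 72 h (a lower number here means a stronger inhibitor, a higher number a weaker inhibitor), compound 2 gives 18200 nM, the lowest of the two numbers; compound 1 gives 39800 nM, a gap beyond the scatter. Compound 3 `CCCCNC(=O)c1c(N)sc(-c2ccc(Cl)cc2)c1-c1ccc(Cl)cc1` differs from compound 2 in one place: propyl in place of 4-methoxyphenyl on a saturated chain carbon bound to an amide-type nitrogen. Among the compounds with values here, no measured pair shows this change, so the size of the step in this assay is uncertain; a modest rise in the number is expected, though a step within the scatter cannot be excluded. Compound 3 is therefore estimated at 35000 nM, with a range of 12000 nM to 100000 nM, a step of a 1.9-fold higher number from compound 2 to compound 3 (0.28 log units; within the scatter).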

Compound 3, half-maximal inhibitory concentration: 8170 nM
Compound 3: the middle estimate sits 4.3-fold (0.63 log units) above what was measured; measured number outside the range, below it.
By their numbers in this assay, from the lowest: compound 3; then compound 2; then compound 1.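

In this assay, propyl in place of 4-methoxyphenyl on a saturated chain carbon bound to an amide-type nitrogen gives a 2.2-fold lower number from compound 2 to compound 3 (0.35 log units; beyond the scatter). Within the data shown here, this is the first one-place comparison, and it shows that a group with no ring and no hydrogen-bond acceptor gives the lower number at this place. Nothing available explains the step.

The compounds shown leave open whether a longer chain or an amine at this place would lower the number further. They also leave open whether an unsubstituted phenyl would behave like propyl or like 4-methoxyphenyl.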